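The source may report more compounds than this note shows. Statements on the series, on what has been measured and on what is new or still open speak of the compounds shown alone.

Values so far in a functional assay on SEM cells (Homo sapiens) for cytotoxicity, with a stated time of 72 h (a lower number here means that less compound is needed, a higher number that more compound is needed for the effect), for the series
- compound 1 (`C=C[C@@](C)(/C=C/c1ccc(O)c(/C=C/C(=O)OCC)c1)CCC=C(C)C`) gives > 36600 nM as a limit of the assay
- compound 2 (`COc1ccc(/C=C/[C@@](C)(/C=C/c2ccc(O)c(C=O)c2)CCC=C(C)C)cc1`) gives 4550 nM
- compound 3 (`COc1ccc(/C=C/[C@@](C)(/C=C/c2ccc(O)c(/C=C/C#N)c2)CCC=C(C)C)cc1`) gives 4540 nM

Among the measured compounds shown here, compound 3 holds one of only two actual numbers here, and its nearest neighbour lies within the scatter of it. Compound 4 (`CCOC(=O)/C=C/c1cc(/C=C/[C@](C)(/C=C/c2ccc(OC)cc2)CCC=C(C)C)ccc1O`) differs from compound 3 as follows: ethoxycarbonyl in place of cyano on a double-bonded chain carbon bound to a double-bonded chain carbon, so 2-cyanoethenyl becomes 2-(ethoxycarbonyl)ethenyl.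

For the measured compounds named here, only one measured step touches this substituent, a 1.0-fold lower number from compound 2 to compound 3 (0.00 log units; within the scatter), and it is a different exchange from the one at hand. Compound 1 also carries 2-(ethoxycarbonyl)ethenyl, and its value is a limit. Going by the values given here, no measured step links compound 1 to compound 4, so it gives no step size.

Among the compounds with values here, with a 1.0-fold lower number from compound 2 to compound 3 (0.00 log units; within the scatter) as the only guide, no shift beyond the scatter is expected in this assay, though this rests on thin evidence. The estimated step is a 1.1-fold higher number from compound 3 to compound 4 (0.04 log units; within the scatter) and so none beyond the scatter. For compound 4 the expected value is 5000 nM, with an estimated range from 1800 nM to 14000 nM for the measurement.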

Compound 4, half-maximal effective concentration: > 36600 nM
Compound 4: no number, only a limit; the forecaster's own chance of this, stated with the estimate: 15%; middle value at least 7.3-fold (0.86 log units) from the limit.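

In this assay, this position does not tolerate every group: formyl and 2-cyanoethenyl read alike, but 2-(ethoxycarbonyl)ethenyl gives an at least 8.0-fold higher number from compound 3 to compound 4 (0.90 log units; beyond the scatter) and an at least 8.0-fold higher number from compound 2 to compound 4 (0.90 log units; beyond the scatter). The step between compound 1 and compound 4 cannot be read, as both values are limits. Cyano to ethoxycarbonyl is thus the only exchange at this position that moves the value beyond the scatter, and its full size remains unknown, with the value of compound 4 only a limit: the limit of > 36600 nM in this assay, at which 2 of the 4 values shown sit.

From the compounds shown here alone, whether the ethyl part or the carbonyl carries this shift remains open; a carboxylic acid or a methyl ester in place of ethoxycarbonyl would separate the two. Also open, going by these compounds, is whether a 2-cyanoethenyl group or a formyl group would restore a measurable value in the core of compound 1.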